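The compounds below may be only part of what the source reports. "The series", "measured", "known", "first", "only" and "open" are said of these compounds alone.

Measured compounds in a functional assay on NCI/ADR-RES cells (Homo sapiens) for cytotoxicity, read by sulforhodamine B assay, with a stated time of 48 h, tested at 0.001 uM; on this read-out higher numbers stand for a weaker effect at the one concentration tested and lower numbers for a stronger effect:
compound 1 `COc1cc(C)cc(-c2c(-c3ccnc(-c4ccc(C(C)=O)cc4)c3)cnn2CC#N)c1`, 95%
compound 2 `COc1cc(C)cc(-c2nn(CC#N)cc2-c2ccnc(-c3ccc(N(C)C)cc3)c2)c1`, 96%
compound 3 `Cc1cc(O)cc(-c2nn(CC#N)cc2-c2ccnc(-c3ccc(N(C)C)cc3)c2)c1`, 97%

Compound 1 gives the lowest of the three numbers, yet compound 2 is within the scatter of it and compound 3 also, so the three stand level. Among the measured compounds shown here, the one single-place step, a number 1 percentage points higher from compound 2 to compound 3 (within the scatter), concerns a different change and is within the scatter. Compound 4 `COc1cc(C)cc(-c2c(-c3ccnc(-c4ccc(N(C)C)cc4)c3)cnn2CC#N)c1` differs from compound 1 by dimethylamino in place of acetyl on an aromatic carbon. For the measured compounds named here, compound 2 carries the same dimethylamino group on a differently joined core, and its value against compound 1 shows no gap beyond the scatter; no measured step touches the acetyl itself. In this assay a step of a number 1 percentage points higher from compound 1 to compound 4 (within the scatter) is therefore expected, none beyond the scatter. Compound 4 is estimated at 96%, between 88% and 103%.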

Compound 4, a percentage reported as activity, at one concentration (the size of the read-out at that concentration, not a potency): 96%
Compound 4: the middle estimate sits on the measured number at the digits printed; low and high end bracket the measured number.
By their numbers in this assay, from the lowest: compounds 1, 2, 4 and 3 (each within the scatter of the next).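

Among the compounds shown here, exchanging 4-acetylphenyl for 4-(dimethylamino)phenyl in this assay gives a number 1 percentage points higher from compound 1 to compound 4 (within the scatter) as the first measured step at this aromatic carbon, para to a large group. At the one concentration tested, this read-out does not separate the acetyl and dimethylamino groups at this place on the core of compound 1. No measured evidence bears on this result.

Open, from the compounds shown here alone, is whether a carboxylic acid or a morpholine ring at the same place would give a step beyond the scatter. Also open, going by these compounds, is whether a higher concentration would separate compound 1 from compound 4.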